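The source may report more compounds than this note shows. Statements on the series, on what has been measured and on what is new or still open speak of the compounds shown alone.

Measured so far in a functional assay on NCI-H1975 cells (Homo sapiens) for inhibition, read by MTT assay, with a stated time of 72 h; on this read-out higher numbers stand for weaker inhibition and lower numbers for stronger inhibition:
compound 1 `C=CC(=O)Nc1cccc(NC(=O)CSc2nc(Nc3ccccc3C)c3ccccc3n2)c1`, 9920 nM;
compound 2 `C=CC(=O)Nc1cccc(NC(=O)CSc2nc(Nc3ccc(CC)cc3)c3ccccc3n2)c1`, 8270 nM.

Going by the values given here, compound 2 holds the lowest of the two numbers, and its only neighbour is compound 1, whose difference a 1.2-fold lower number from compound 1 to compound 2 (0.08 log units; within the scatter) lies within the scatter. Compound 3 `C=CC(=O)Nc1cccc(NC(=O)CSc2nc(Nc3ccc(F)c(Cl)c3)c3ccccc3n2)c1` differs from compound 2 by 3-chloro-4-fluorophenyl in place of 4-ethylphenyl on a nitrogen on an aromatic ring. Among the compounds with values here, only the step from compound 1 to compound 2 touches this position, and it was within the scatter, so no firm direction is known. Compound 3 is therefore expected to give about 7000 nM, between 2500 nM and 20000 nM, a step of a 1.2-fold lower number from compound 2 to compound 3 (0.07 log units; within the scatter) that is estimated not to exceed the scatter.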

Compound 3, half-maximal inhibitory concentration: > 50000 nM
Compound 3 gave a limit, no number; the forecaster's own chance of this, stated with the estimate: 10%; at least 7.1-fold (0.85 log units) between middle value and limit.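

Placing 3-chloro-4-fluorophenyl on this nitrogen weakens inhibition, with an at least 6.0-fold higher number from compound 2 to compound 3 (0.78 log units; beyond the scatter) and an at least 5.0-fold higher number from compound 1 to compound 3 (0.70 log units; beyond the scatter), whereas exchanging 2-methylphenyl for 4-ethylphenyl had stayed within the scatter. So the group at this position can matter, and halogens on this ring go with weaker inhibition in the one compound shown that carries them. The result for compound 3 is a limit, not a number: the limit of > 50000 nM in this assay, at which 1 of the 3 values shown sits.

On these data alone, the true size of both steps therefore stays open. Also open, as far as these compounds go, is whether chlorine alone or fluorine alone would do the same, and how a phenyl ring bearing an amine or a carboxylic acid would behave here.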